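A few compounds are considered here, and "the series" means these few. Any claim that something is new, unique, unknown or untested is made for them only; others in the source may bear on it.

In a physicochemical assay for lipophilicity (on this read-out higher numbers stand for higher lipophilicity and lower numbers for lower lipophilicity), compound 2 `N#Cc1cccc(S(=O)(=O)N(Cc2ccc(F)cc2)C[C@@H]2CCC(=O)N2)c1` stands lowest of the two measured compounds at 2.7, while compound 1 `O=C1CC[C@@H](CN(Cc2ccc(F)cc2)S(=O)(=O)c2cccc(Cl)c2)N1` gives 3.6. Among the measured compounds shown here, the only measured step, a number 0.90 log units lower from compound 1 to compound 2 (beyond the scatter), is modest and concerns cyano in place of chloro on an aromatic carbon, so it bears only indirectly on what follows. Compound 3 `N#Cc1cccc(S(=O)(=O)N(Cc2ccc(F)cc2)C[C@@H]2CCCC(=O)N2)c1` differs from compound 2 thus: 6-oxopiperidin-2-yl in place of 5-oxopyrrolidin-2-yl on a saturated chain carbon bound to a sulfonamide nitrogen. For the measured compounds named here, no measured step covers this change, so only a small upward step is expected, a number 0.40 log units higher from compound 2 to compound 3 (beyond the scatter). For compound 3 the estimated value is 3.1, within a range of 2.7 to 3.5.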

Compound 3, distribution coefficient: 2.9
Compound 3: middle estimate off by 0.20 log units, on the high side; low and high end bracket the measured number.
By their numbers in this assay, from the lowest: compounds 2 and 3 (each within the scatter of the next); then compound 1.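

In this assay, among the compounds shown here, the earlier compounds spoke only to a change on an aromatic carbon, whereas this is the first reading at the saturated chain carbon bound to a sulfonamide nitrogen, and it gives a number 0.20 log units higher from compound 2 to compound 3 (within the scatter). On this read-out, then, the six-membered ring with one more carbon is not told apart from the five-membered ring at this place. No measured evidence is at hand to account for this result.

On these data alone, what an amine or a carboxylic acid on the chain at this place would give remains open. So does whether the same ring change reads alike with chloro in place of cyano on the aromatic carbon.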